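The source may report more compounds than this note shows. Statements on the series, on what has been measured and on what is new or still open speak of the compounds shown alone.

- Compound 1 `CC1=CC[C@@H]([C@@](C)(O)CCCC(C)(C)NC(=S)N/N=C\c2ccc(C)cc2)CC1`: 6020 nM
- Compound 2 `CC1=CC[C@@H]([C@@](C)(O)CCCC(C)(C)NC(=S)N/N=C\c2ccc(N(C)C)cc2)CC1`: 3600 nM

Among the compounds with values here, in a functional assay on OVCAR-3 cells (Homo sapiens) for cytotoxicity, read by sulforhodamine B assay (on this read-out higher numbers stand for weaker inhibition of growth and lower numbers for stronger inhibition of growth), only two compounds have numbers so far. Compound 2, at 3600 nM, cannot be told apart from compound 1, at 6020 nM. The next compound, compound 3 `CC1=CC[C@@H]([C@@](C)(O)CCCC(C)(C)NC(=S)N/N=C\c2cccc([N+](=O)[O-])c2)CC1`, keeps the shared core and alters the aromatic part: 3-nitrophenyl in place of 4-(dimethylamino)phenyl on a carbon with a double bond to nitrogen. In words, this is 3-nitrophenyl in place of 4-(dimethylamino)phenyl on a carbon with a double bond to nitrogen.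

Within the data shown here, one measured step bears on this change: a 1.7-fold lower number from compound 1 to compound 2 (0.22 log units; within the scatter), which came from dimethylamino in place of methyl on an aromatic carbon. It concerns the same part of the molecule and stays within the scatter. Among the measured compounds shown here, no measured compound carries a nitro group, so the data give no direction for this new group. For the measured compounds named here, with a 1.7-fold lower number from compound 1 to compound 2 (0.22 log units; within the scatter) as the only guide, no step beyond the scatter is expected, although one step is thin evidence. The expected change is a 1.3-fold higher number from compound 2 to compound 3 (0.10 log units; within the scatter). Compound 3 is expected at 4500 nM, with an estimated range of 1800 nM to 11000 nM.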

Compound 3, concentration for 50% growth inhibition: 8510 nM
Estimate against measurement, compound 3: 1.9-fold (0.28 log units) below; low and high end bracket the measured number.
By their numbers in this assay, from the lowest: compounds 2, 1 and 3 (each within the scatter of the next, the first and the last beyond it).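

In this assay, within the data shown here, the group on the carbon with a double bond to nitrogen now gives a step beyond the scatter for the first time: a 2.4-fold higher number from compound 2 to compound 3 (0.37 log units; beyond the scatter) when 3-nitrophenyl replaces 4-(dimethylamino)phenyl, a modest but readable difference at this position. The same 3-nitrophenyl set against 4-methylphenyl gives a 1.4-fold higher number from compound 1 to compound 3 (0.15 log units; within the scatter) and stays within the scatter, so only compound 2 and compound 3 can be told apart, while compound 1 cannot be separated from either. The compounds shown offer no measured basis for explaining the step between compound 2 and compound 3.

The names 3-nitrophenyl and 4-(dimethylamino)phenyl differ both in the group and in its number on the ring, so these compounds do not show which of the two differences carries the step. As far as these compounds go, it also remains open how a phenyl with no added group, or one bearing a chlorine or a carboxylic acid, would read here, and how changes elsewhere in the shared core would affect growth inhibition.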